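From Isopropyl to 3-Chlorophenyl on a Nitrogen

A few compounds are considered here, and "the series" means these few. Any claim that something is new, unique, unknown or untested is made for them only; others in the source may bear on it.

- Compound 1 `C#Cc1cccc(Nc2ncnn3ccc(COC[C@@H]4CNCCO4)c23)c1`: 3900 nM
- Compound 2 `Cn1ncc2cc(Nc3ncnn4ccc(CN5CCC(N)CC5)c34)ccc21`: "not active" (no number reported)
- Compound 3 `CC(C)Nc1ncnn2ccc(CN3CCC(N)CC3)c12`: "not determined" (no result reported)

In a functional assay on A2780 cells (Homo sapiens) for antiproliferative activity (on this read-out higher numbers stand for weaker inhibition and lower numbers for stronger inhibition), compound 3 has no single number, and its entry reads "not determined" (no result reported). It therefore offers no starting value. Compound 4 `NC1CCN(Cc2ccn3ncnc(Nc4cccc(Cl)c4)c23)CC1` has not yet been measured. The change is 3-chlorophenyl in place of isopropyl on a nitrogen on an aromatic ring, which puts 3-chlorophenyl in place of isopropyl on a nitrogen on an aromatic ring. Among the compounds with values here, no size of step can be worked out in this assay, and only a loose direction towards measurable inhibition is expected. That expectation rests on compound 1, which has an aromatic ring on that nitrogen and gives 3900 nM. Compound 2 goes against it, with "not active" (no number reported). The estimate for compound 4 is 3000 nM, with an expected range from 700 nM to 12000 nM.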

Compound 4, half-maximal inhibitory concentration: > 5000 nM
Compound 4: only a limit was reported; the forecaster's own chance of this, stated with the estimate: 30%; at least 1.6-fold (0.22 log units) between middle value and limit.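

Compound 4 gives > 5000 nM, which is a limit of the assay and not a number. Within the data shown here, with no result for compound 3, no step between compound 3 and compound 4 can be read. From the compounds shown here alone, how far 3-chlorophenyl in place of isopropyl shifts inhibition in this assay stays open.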